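The compounds below may be only part of what the source reports. "The series", "measured", "known", "first", "only" and "open" are said of these compounds alone.

Going by the values given here, compound 3, `COc1ccccc1-c1ccc(CN(CC(=O)C(C)(C)O)C(=O)NC2CCN(Cc3ccc(C)cc3)CC2)cc1`, is one of three compounds measured in an in vitro functional assay on HEK293 cells for antagonist activity at melanin-concentrating hormone receptor 1 (Homo sapiens), read by GTPgammaS binding, with a stated time of 45 min; a lower number here means a stronger inhibitor, a higher number a weaker inhibitor. Compound 3 gives 3730 nM, the second highest of the three numbers. Its nearest neighbour is compound 2, `Cc1ccc(CN2CCC(NC(=O)N(CC(=O)C(C)(C)O)Cc3ccc(-c4ccc(F)cc4)cc3)CC2)cc1`, which gives 4530 nM in this assay; the two lie within the scatter of each other. Furthest away is compound 1, `Cc1ccc(CN2CCC(NC(=O)NCc3ccc(-c4cccc(C#N)c4)cc3)CC2)cc1`, which gives 411 nM in this assay, well beyond the scatter from compound 3.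

The step from compound 3 to compound 4, `Cc1ccc(CN2CCC(NC(=O)N(CC(=O)C(C)(C)O)Cc3ccc(-c4cccc(C#N)c4)cc3)CC2)cc1`, is the change (3-cyanophenyl in place of 2-methoxyphenyl on an aromatic carbon). Among the compounds with values here, the only measured step that bears on it is the exchange of one aryl group for another on the same carbon, a 1.2-fold lower number from compound 2 to compound 3 (0.08 log units; within the scatter), which stayed within the scatter. Within the data shown here, compound 1 carries the same 3-cyanophenyl as compound 4 but lacks the chain on the urea nitrogen, and no single step connects it to compound 4, so its lower number cannot be carried over directly. Because a 1.2-fold lower number from compound 2 to compound 3 (0.08 log units; within the scatter) showed no movement beyond the scatter, compound 4 is expected to land close to compound 3, a step of a 1.1-fold lower number from compound 3 to compound 4 (0.03 log units; within the scatter) in this assay. Compound 4 is therefore estimated at 3500 nM in this assay, with a range from 1200 nM to 10000 nM.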

Compound 4, antagonist equilibrium constant: 5000 nM
Beside the measured number, compound 4's estimate is 1.4-fold (0.15 log units) below it; low and high end bracket the measured number.
By their numbers in this assay, from the lowest: compound 1; then compounds 3, 2 and 4 (each within the scatter of the next).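

In this assay, exchanging the aryl group on an aromatic carbon, para to a large group, gives a 1.3-fold higher number from compound 3 to compound 4 (0.13 log units; within the scatter) and a 1.1-fold higher number from compound 2 to compound 4 (0.04 log units; within the scatter), so 3-cyanophenyl, 2-methoxyphenyl and 4-fluorophenyl all lie within the scatter of one another when the ((1-hydroxy-1-methylethyl)carbonyl)methyl chain is on the amide-type nitrogen. With 3-cyanophenyl held constant, placing that chain in place of hydrogen gives a 12-fold higher number from compound 1 to compound 4 (1.09 log units; beyond the scatter) and this is the first single-place step in the series to lie beyond the scatter, so among these compounds the larger change comes from the nitrogen substituent and not from the aryl exchange. No measured evidence is available to explain either result.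

Compound 1 is the only compound shown with hydrogen on that nitrogen, so it remains open whether the aryl exchange would also stay within the scatter in that setting. From the compounds shown here alone, it also remains open where a methyl group, a longer alkyl chain, or a chain ending in an amine or a carboxylic acid on that nitrogen would fall relative to compound 1 and compound 4.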